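The compounds below may be only part of what the source reports. "The series", "measured", "known", "first", "only" and "open" are said of these compounds alone.

Working notes on the series. Compound 3 `Oc1cccc(-c2cc(-c3ccccc3C(F)(F)F)cc(-c3cccc(O)c3)n2)c1` carries a 2-(trifluoromethyl)phenyl group on the shared core and in a functional assay on HCT-15 cells (Homo sapiens) for inhibition (a higher number here means a weaker inhibitor, a lower number a stronger inhibitor), gives 8150 nM. Of the two numbers in hand it is the higher, the other being that of compound 1 `Oc1cccc(-c2cc(-c3cccc(F)c3)cc(-c3cccc(O)c3)n2)c1`, which in this assay gives 7860 nM; the two lie within the scatter of each other, so no order between them is claimed. Compound 2 `Oc1cccc(-c2cc(-c3ccc(C(F)(F)F)cc3)cc(-c3ccccc3O)n2)c1`, which carries a 4-(trifluoromethyl)phenyl group together with a 2-hydroxyphenyl group, reaches only a limit in this assay, > 50000 nM. The change from compound 3 to compound 4 `Oc1cccc(-c2cc(-c3ccc(C(F)(F)F)cc3)cc(-c3cccc(O)c3)n2)c1` is 4-(trifluoromethyl)phenyl in place of 2-(trifluoromethyl)phenyl on an aromatic carbon. For the measured compounds named here, the one measured step that bears on exchanging the group at this place is a 1.0-fold higher number from compound 1 to compound 3 (0.02 log units; within the scatter), which did not move the number beyond the scatter. Compound 2 differs from compound 4 in a second place as well, so its value cannot be read as a step to compound 4, and it stands only as a limit (the limit of > 50000 nM in this assay, at which 1 of the 3 values shown sits). On the strength of the measured step alone, the expected step is a 1.5-fold higher number from compound 3 to compound 4 (0.17 log units; within the scatter), with the limit of compound 2 widening the upper side. Compound 4 is therefore expected to give 12000 nM, between 4000 nM and 50000 nM.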

Compound 4, half-maximal inhibitory concentration: > 50000 nM
Compound 4 gave a limit, no number; the forecaster's own chance of this, stated with the estimate: 25%; at least 4.1-fold (0.61 log units) between middle value and limit.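

For the compounds shown here, at the place opposite the ring nitrogen, the position of the trifluoromethyl group on the phenyl ring matters in this assay: replacing 2-(trifluoromethyl)phenyl with 4-(trifluoromethyl)phenyl gives an at least 6.1-fold higher number from compound 3 to compound 4 (0.78 log units; beyond the scatter) and is the first step beyond the scatter at this place. The exchange of 3-fluorophenyl for 4-(trifluoromethyl)phenyl likewise gives an at least 6.3-fold higher number from compound 1 to compound 4 (0.80 log units; beyond the scatter), whereas the earlier exchange at this place, a 1.0-fold higher number from compound 1 to compound 3 (0.02 log units; within the scatter), did not show that this place could respond to a change of group. Compound 2 and compound 4 both stand as limits, so the step between them cannot be read and the change from 2-hydroxyphenyl to 3-hydroxyphenyl stays without a size in this pair: the limit of > 50000 nM in this assay, at which 2 of the 4 values shown sit.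

From the compounds shown here alone, whether the loss belongs to the trifluoromethyl group at this ring position or to any group there stays open, and a 4-fluorophenyl or 4-aminophenyl group at this place would separate the two. Going by these compounds, compound 4 is a limit, so the upper size of both readable steps also remains open.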